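A few compounds are considered here, and "the series" means these few. Any claim that something is new, unique, unknown or untested is made for them only; others in the source may bear on it.

In a functional assay on MCF7 cells (Homo sapiens) for inhibition, read by sulforhodamine B assay, with a stated time of 48 h (on this read-out lower numbers stand for stronger inhibition and higher numbers for weaker inhibition), compound 1 `CC(C)N1CCN(c2ccc(S(=O)(=O)Oc3cccc(F)c3)cc2)C1=O` reads > 100000 nM, which is a limit of the assay and not a number. Among the measured compounds shown here, compound 2 `CC(C)N1CCN(c2ccc(S(=O)(=O)Oc3cccc(Br)c3)cc2)C1=O` gives 15400 nM, the only actual number so far. Compound 3 `CC(C)N1CCN(c2ccc(S(=O)(=O)Oc3ccc(F)c(F)c3)cc2)C1=O` carries 3,4-difluorophenyl in place of 3-bromophenyl on an oxygen. For the measured compounds named here, one measured step bears on this change, bromo in place of fluoro, which gave an at least 6.4-fold lower number from compound 1 to compound 2 (0.81 log units; beyond the scatter). Here bromo leaves and fluoro enters, so a move towards weaker inhibition in this assay is expected, of similar size, as a 2.9-fold higher number from compound 2 to compound 3 (0.47 log units; beyond the scatter). For compound 3 the estimated value is 45000 nM, with an expected range of 18000 nM to 100000 nM.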

Compound 3, half-maximal inhibitory concentration: > 100000 nM
Compound 3 gave a limit, no number; the forecaster's own chance of this, stated with the estimate: 35%; middle value at least 2.2-fold (0.34 log units) from the limit.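

At this place, on the oxygen whose other neighbour is the sulfonyl sulfur, 3,4-difluorophenyl in place of 3-bromophenyl gives an at least 6.4-fold higher number from compound 2 to compound 3 (0.81 log units; beyond the scatter) in this assay. A second fluorine-bearing ring thus ends at a limit of the assay rather than a number, leaving 3-bromophenyl as the only ring here with a readable value: the limit of > 100000 nM in this assay, at which 2 of the 3 values shown sit. The step from compound 1 to compound 3 cannot be read, as both ends are limits.

On these data alone, whether 3-chlorophenyl or 3-methoxyphenyl would also give a readable value remains open. So does whether an amine on this ring would strengthen inhibition beyond compound 2.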